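Methoxy to hydroxy on compound 2

The compounds below may be only part of what the source reports. "The series", "measured", "known", "first", "only" and "open" are said of these compounds alone.

Measured in a functional assay on MCF7 cells (Homo sapiens) for antiproliferative activity, read by MTT assay, with a stated time of 72 h (a higher number here means a weaker inhibitor, a lower number a stronger inhibitor), so far:
compound 1 `Cc1ccc(N(C)S(=O)(=O)C2CC3OC2C(c2ccc(NC(=O)CCCCCCC(=O)O)cc2)=C3c2ccc(O)cc2)cc1` gives 23200 nM
compound 2 `CCN(c1ccc(OC)cc1)S(=O)(=O)C1CC2OC1C(c1ccc(NC(=O)CCCCCCC(=O)O)cc1)=C2c1ccc(O)cc1` gives 20300 nM

Compound 2 at 20300 nM sits within the scatter of compound 1 at 23200 nM and the two cannot be ranked. Compound 3 (`CCN(c1ccc(O)cc1)S(=O)(=O)C1CC2OC1C(c1ccc(NC(=O)CCCCCCC(=O)O)cc1)=C2c1ccc(O)cc1`) differs from compound 2 in one place (hydrogen in place of methyl on an oxygen on an aromatic ring), with hydrogen in place of methyl on an oxygen on an aromatic ring. This turns methoxy to hydroxy and 4-methoxyphenyl to 4-hydroxyphenyl. Going by the values given here, only one measured step bears on this change: a 1.1-fold lower number from compound 1 to compound 2 (0.06 log units; within the scatter) came with ethyl(4-methoxyphenyl)amino in place of methyl(4-methylphenyl)amino on a sulfonyl sulfur, the same group now altered. That step stayed within the scatter. Among the compounds with values here, it is thin evidence: no measured pair here exchanges methyl for hydrogen on that oxygen. In this assay no step beyond the scatter is expected, and the estimated step is a 1.0-fold lower number from compound 2 to compound 3 (0.01 log units; within the scatter) as a working figure. The expected value for compound 3 is 20000 nM (estimated range 10000 nM to 40000 nM).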

Compound 3, half-maximal inhibitory concentration: 46600 nM
For compound 3 the middle estimate is 2.3-fold (0.37 log units) below the measured one; the measured number lies above the stated range.
By their numbers in this assay, from the lowest: compounds 2, 1 and 3 (each within the scatter of the next, the first and the last beyond it).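

In this assay, the change from methoxy to hydroxy on the 4-methoxyphenyl group gives a 2.3-fold higher number from compound 2 to compound 3 (0.36 log units; beyond the scatter), a modest step and the first in this set to pass beyond the scatter. Going by these compounds alone, the earlier change to the same group on the sulfonyl sulfur, a 1.1-fold lower number from compound 1 to compound 2 (0.06 log units; within the scatter), separated nothing, so this oxygen substituent is the first point at which the read-out responds to a single edit. The separation holds only against compound 2, since a 2.0-fold higher number from compound 1 to compound 3 (0.30 log units; within the scatter) stays within the scatter, and the result therefore ranks compound 3 above compound 2 by number but not above compound 1. No evidence is available on what lies behind this step.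

Still open, from the compounds shown here alone, is whether an amino group or a fluorine in place of that hydroxy would track with compound 2 or with compound 3. A single pair also leaves open whether the same exchange of methyl for hydrogen on the oxygen gives a step of similar size when the ethyl on the sulfonamide nitrogen is replaced by a methyl or a propyl chain.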